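The source may hold more compounds than are shown below. What is called first, only, known or untested is meant among the compounds shown, and "the series" means these compounds.

Measured compounds in an assay on HEK293 cells for inhibition of solute carrier family 12 member 2 (Homo sapiens), read by fluorescence, with a stated time of 30 min, tested at 100 uM; a higher number here means a stronger effect of the compound at the concentration tested, a lower number a weaker effect:

compound 1, `CCCCCCNc1ccc([N+](=O)[O-])cc1S(N)(=O)=O`, gives 3.8%
compound 2, `CCCCCCCCNc1ccc([N+](=O)[O-])cc1S(N)(=O)=O`, gives 5.8%
compound 3, `CCCCNc1ccc([N+](=O)[O-])cc1S(=O)(=O)N(C)C`, gives 15.2%

Compound 1 and compound 2 differ in one place only: ethyl in place of hydrogen on a saturated chain carbon, six bonds along the chain from a nitrogen on an aromatic ring. The step that this change made in this assay is a number 2 percentage points higher from compound 1 to compound 2 (within the scatter). Compound 3 stands highest of the three numbers, yet its gap to compound 2 lies within the scatter and only its gap to compound 1 lies beyond it, so no ordering among these three is asserted here.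

Compound 4, `CCCCCCNc1ccc([N+](=O)[O-])cc1S(=O)(=O)N(C)C`, is not yet measured. It differs from compound 3 by ethyl in place of hydrogen on a saturated chain carbon, four bonds along the chain from a nitrogen on an aromatic ring. How the core of compound 3 differs from the core of compound 1 is not broken down here; the two are built from the same atoms joined differently. Among the compounds with values here, the change from compound 3 to compound 4 is the same kind of change as the one from compound 1 to compound 2, not the same change: in the measured pair the ethyl enters six bonds along the chain from a nitrogen on an aromatic ring, in the new pair four bonds along the chain from that nitrogen.

In this assay, within the data shown here, the step from compound 3 to compound 4 is expected to be a number 1.8 percentage points higher from compound 3 to compound 4 (within the scatter), an expectation resting on the single measured instance of this kind of change, a number 2 percentage points higher from compound 1 to compound 2 (within the scatter), which stayed within the scatter. Compound 4 is therefore estimated at 17%, with a likely range from 6% to 30%.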

Compound 4, a percentage reported as inhibition, at one concentration (the size of the read-out at that concentration, not a potency): 4.9%
Compound 4: the middle estimate sits 12.1 percentage points above what was measured; measured number below the stated range.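

In this assay, ethyl in place of hydrogen on a saturated chain carbon gave a number 10.3 percentage points lower from compound 3 to compound 4 (beyond the scatter), whereas the same kind of change on the core of compound 1 stayed within the scatter, and the two steps cannot be told apart: the same change on two cores in this assay, a number 2 percentage points higher (within the scatter) from compound 1 to compound 2 and a number 10.3 percentage points lower (beyond the scatter) from compound 3 to compound 4, 12.3 percentage points apart, within the scatter of two such steps

The series therefore does not show that this change behaves differently on the two cores, nor does it establish that the change carries over from one to the other, as the evidence is a single pair of steps that also place the ethyl at different distances along the chain from the nitrogen. Dimethylamino in place of amino on a sulfonyl sulfur gave a number 1.1 percentage points higher from compound 1 to compound 4 (within the scatter), so with this chain the compounds shown resolve no effect of that replacement.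

Going by these compounds, it remains open whether a longer chain, such as octyl, on the core of compound 3 would give a number that separates from those of the other compounds, which would show whether the step seen with ethyl continues. The compounds shown also leave open what a cyclic amine on the sulfonyl sulfur, or a carboxylic acid in place of the nitro group, would do in this assay.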